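Swapping the End Group Back on a Shorter Chain

A few compounds are considered here, and "the series" means these few. Any claim that something is new, unique, unknown or untested is made for them only; others in the source may bear on it.

Among the compounds with values here, in a functional assay on Hep 3B2 cells (Homo sapiens) for inhibition, read by MTT assay, with a stated time of 72 h (a higher number here means a weaker inhibitor, a lower number a stronger inhibitor), compound 2 (`CNC(=O)CCCCCCCn1nc(-c2ccc3oc(N)nc3c2)c2c(N)ncnc21`) gives 10300 nM, the lower of the two numbers so far, while compound 1 (`Nc1nc2cc(-c3nn(CCCCCC(=O)NO)c4ncnc(N)c34)ccc2o1`) gives 34200 nM. The next compound, compound 3 (`Nc1nc2cc(-c3nn(CCCCCCC(=O)NO)c4ncnc(N)c34)ccc2o1`), has not been measured. Its change from compound 2 is hydroxycarbamoyl in place of (methylcarbamoyl)methyl on a saturated chain carbon, six bonds along the chain from an aromatic nitrogen. Put simply, hydroxycarbamoyl takes the place of (methylcarbamoyl)methyl on a saturated chain carbon, six bonds along the chain from an aromatic nitrogen. Within the data shown here, only one measured step bears on this: a 3.3-fold lower number from compound 1 to compound 2 (0.52 log units; beyond the scatter). That step removed hydroxycarbamoyl, so bringing the group back should raise the number. The match is only partial, since that step acted five bonds along the chain, so a smaller step is expected. The expected change is a 2.1-fold higher number from compound 2 to compound 3 (0.33 log units; beyond the scatter). The estimate for compound 3 is 22000 nM, within an expected range of 7000 nM to 60000 nM.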

Compound 3, half-maximal inhibitory concentration: 14000 nM
Compound 3: the middle estimate sits 1.6-fold (0.20 log units) above what was measured, and the stated range covers the measured number.
By their numbers in this assay, from the lowest: compounds 2 and 3 (each within the scatter of the next); then compound 1.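

In this assay, putting hydroxycarbamoyl in place of (methylcarbamoyl)methyl gives a 1.4-fold higher number from compound 2 to compound 3 (0.13 log units; within the scatter), so this end-group change leaves no readable difference at this place on the chain. Within the data shown here, with hydroxycarbamoyl kept at the chain end, (hydroxycarbamoyl)methyl in place of hydroxycarbamoyl gives a 2.4-fold lower number from compound 1 to compound 3 (0.39 log units; beyond the scatter), a change the earlier compounds could not show apart from a change of end group, since the step to compound 2 altered both chain and end together. No measurement shown here explains either result.

As far as these compounds go, whether a still longer chain ending in hydroxycarbamoyl would extend this step remains open. So does how a carboxylic acid or a primary amide at the chain end would compare with the two end groups shown here.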